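Swapping chloro for methyl on the aryl ether of compound 1

The source may report more compounds than this note shows. Statements on the series, on what has been measured and on what is new or still open speak of the compounds shown alone.

The series shares a thiazolidinedione core carrying a diaryl ether, and three members have numbers in a functional assay for agonist activity at Free fatty acid receptor 1 (Homo sapiens), read by FLIPR, in the presence of a further agent that is not named here; on this read-out lower numbers stand for an effect already at smaller amounts and higher numbers for an effect only at larger amounts of compound. Compound 1 `O=C1NC(=O)C(Cc2ccc(Oc3cccc(Cl)c3)cc2)S1` gives 318 nM in this assay, the highest of the three numbers, though both gaps to its neighbours lie within the scatter: compound 2 `Cc1cc(C(F)(F)F)cc(Oc2ccc(CC3SC(=O)NC3=O)cc2)n1` gives 218 nM, and compound 3 `O=C1NC(=O)C(Cc2ccc(Oc3cc(Cl)cc(Cl)c3)cc2)S1` gives 207 nM. For the measured compounds named here, the single one-place step among them, a 1.5-fold lower number from compound 1 to compound 3 (0.19 log units; within the scatter), adds a chloro and does not leave the scatter.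

Compound 4 `Cc1cccc(Oc2ccc(CC3SC(=O)NC3=O)cc2)c1` differs from compound 1 by methyl in place of chloro on an aromatic carbon. Going by the values given here, no measured pair exchanges chloro for methyl, so the only guide is that adding or removing a chloro on this ring, as in a 1.5-fold lower number from compound 1 to compound 3 (0.19 log units; within the scatter), changed little. Compound 4 is therefore expected to stay close to compound 1, with a 1.1-fold higher number from compound 1 to compound 4 (0.04 log units; within the scatter) as the expected step, not beyond the scatter. Compound 4 is estimated at 350 nM, with a range from 150 nM to 800 nM.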

Compound 4, half-maximal effective concentration: 203 nM
Compound 4: the middle estimate sits 1.7-fold (0.24 log units) above what was measured; the range from low to high includes it.
By their numbers in this assay, from the lowest: compounds 4, 3, 2 and 1 (each within the scatter of the next).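

In this assay the exchange gives a 1.6-fold lower number from compound 1 to compound 4 (0.19 log units; within the scatter) and so leaves the 3-chlorophenyl and 3-methylphenyl forms indistinguishable on this read-out. The earlier compounds shown here showed only that adding a chloro to this ring stayed within the scatter; this result shows that the chloro already present in compound 1 can also be replaced by methyl, a group of the same heavy-atom count, without a step beyond the scatter. Nothing measured here explains why the two groups read alike.

The compounds shown leave open whether this position would accept an amine, a carboxylic acid or a longer chain such as propyl with an equally small step. They also leave open whether methyl could replace either chloro of compound 3 with the same outcome.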